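Trifluoromethyl on Two Cyclohexyl Esters at the Dopamine Transporter

The compounds below may be only part of what the source reports. "The series", "measured", "known", "first", "only" and "open" are said of these compounds alone.

Measured compounds:
compound 1, `COC(=O)C1=C(c2ccccc2)CCCC1`, 630000 nM
compound 2, `COC(=O)C1=C(c2ccc(C(F)(F)F)cc2)CCCC1`, 590000 nM
compound 3, `COC(=O)[C@@H]1CCCC[C@@H]1c1ccccc1`, 975000 nM

Of the compounds shown here, three have been measured in an assay on COS-1 cells for displacement of a labelled ligand from sodium-dependent dopamine transporter (Homo sapiens); a higher number here means a weaker inhibitor, a lower number a stronger inhibitor. Compound 1 `COC(=O)C1=C(c2ccccc2)CCCC1` gives 630000 nM. Compound 2 `COC(=O)C1=C(c2ccc(C(F)(F)F)cc2)CCCC1` carries a trifluoromethyl in place of hydrogen on an aromatic carbon, the change described as trifluoromethyl in place of hydrogen on an aromatic carbon; the step of a 1.1-fold lower number from compound 1 to compound 2 (0.03 log units; within the scatter) lies within the scatter, so the two values cannot be told apart. Compound 3 `COC(=O)[C@@H]1CCCC[C@@H]1c1ccccc1` gives 975000 nM; its core differs from that of compound 1, and the difference between the two cores is not broken down here. Its value sits within the scatter of both compound 1 and compound 2.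

Compound 4 `COC(=O)[C@@H]1CCCC[C@@H]1c1ccc(C(F)(F)F)cc1` has not yet been measured. It stands to compound 3 as compound 2 stands to compound 1: the change (trifluoromethyl in place of hydrogen on an aromatic carbon), the same change as before, at a place described in the same words. Since that change gave a 1.1-fold lower number from compound 1 to compound 2 (0.03 log units; within the scatter), compound 4 is expected to lie close to compound 3, with an estimated step of a 1.1-fold lower number from compound 3 to compound 4 (0.03 log units; within the scatter) in this assay. The estimate for compound 4 is 900000 nM, expected to fall between 400000 nM and 2000000 nM.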

Compound 4, inhibition constant: 222000 nM
Beside the measured number, compound 4's estimate is 4.1-fold (0.61 log units) above it, outside the stated range (below it).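

In this assay, putting trifluoromethyl in place of hydrogen on an aromatic carbon of compound 3 gives a clear though modest step, a 4.4-fold lower number from compound 3 to compound 4 (0.64 log units; beyond the scatter), so on this core the change does more than the earlier pair would have suggested. The size of the step therefore did not carry over from one core to the other: the same change on two cores in this assay, a 1.1-fold lower number (0.03 log units; within the scatter) from compound 1 to compound 2 and a 4.4-fold lower number (0.64 log units; beyond the scatter) from compound 3 to compound 4, 4.1-fold (0.61 log units) apart, beyond the scatter of two such steps. With a single pair on each core, this shows that the change cannot be assumed to act equally across the two cores, but it does not show which difference between the cores goes with the larger step, or how the change would behave on a further core.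

The compounds shown leave open whether another group at the same place, such as chlorine, methoxy or a nitrile, would also give steps of unequal size on the two cores. They also leave open whether the gap between the cores would persist if the methyl ester were replaced by a carboxylic acid, an amide or a longer ester such as the ethyl ester.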